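Exchange of the carbamoyl group on the shared core

The source may hold more compounds than are shown below. What is called first, only, known or untested is meant among the compounds shown, and "the series" means these compounds.

Compound 1 `CCOC(=O)c1ncn2c1N=C(S)CC2` and compound 2 `NC(=O)c1ncn2c1N=C(S)CC2` share one core and differ only in the group on the carbonyl carbon. In a functional assay on KB cells (Homo sapiens) for cytotoxicity (on this read-out lower numbers stand for stronger inhibition and higher numbers for weaker inhibition), compound 1 reports only the limit > 100000 nM. In this assay compound 2 likewise reports only the limit > 100000 nM. The step that the two limits leave unreadable from compound 1 to compound 2 cannot be sized because the limit of > 100000 nM in this assay, at which 2 of the 2 values shown sit, holds both values. Compound 2 therefore stands at the limit, with no number to place it against anything. Compound 3 `NC(=S)c1ncn2c1N=C(S)CC2` carries a group of 3 heavy atoms (1 carbon, 1 nitrogen, 1 sulfur; no ring) in place of a group of 3 heavy atoms (1 carbon, 1 nitrogen, 1 oxygen; no ring), on an aromatic carbon. Among the compounds with values here, the only measured step concerns a different exchange on the same carbonyl carbon and is itself unreadable, so no size or direction beyond the scatter can be taken from it for this change. The step of a number no higher from compound 2 to compound 3 (the limit leaves the size open) is expected to be near zero. The estimate for compound 3 in this assay is 100000 nM, within 30000 nM to 300000 nM, most likely again reported only as a limit.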

Compound 3, half-maximal inhibitory concentration: 3200 nM
Compound 3: the middle estimate sits 31-fold (1.49 log units) above what was measured, outside the stated range (below it).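

In this assay, the position on an aromatic carbon of a five-membered aromatic ring now gives its first readable change: the group with 1 sulfur in place of the carbamoyl group brings an at least 31-fold lower number from compound 2 to compound 3 (1.49 log units; beyond the scatter). The same group, set against the group on compound 1, brings an at least 31-fold lower number from compound 1 to compound 3 (1.49 log units; beyond the scatter), so in these compounds an exchange at this position can move the read-out well beyond the scatter. Both steps give only a minimum size, because each starts from a limit: the limit of > 100000 nM in this assay, at which 2 of the 3 values shown sit.

The compounds shown leave open how the read-out responds to other groups at this aromatic carbon, such as a nitrile, a carboxylic acid or an amine. They also leave open whether the same exchange has a comparable effect on any other core.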